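Half-life in human liver microsomes: a thiazole for a fluorophenyl

The compounds below may be only part of what the source reports. "The series", "measured", "known", "first", "only" and "open" are said of these compounds alone.

Measured compounds:
- compound 1 `Cc1nc(C)c([C@H](OC(C)(C)C)C(=O)O)c(N2CCC(C)(C)CC2)c1-c1ccc(CCCc2ccc(F)cc2)cc1`: > 2 h
- compound 2 `Cc1nc(C)c([C@H](OC(C)(C)C)C(=O)O)c(N2CCC(C)(C)CC2)c1-c1ccc(OCCCc2ccc(F)cc2)cc1`: > 2 h
- compound 3 `Cc1nc(C)c([C@H](OC(C)(C)C)C(=O)O)c(N2CCC(C)(C)CC2)c1-c1ccc(SCCc2ccc(F)cc2)cc1`: > 2 h

Three compounds share one core and differ only in the side chain on the outer aromatic ring. In an ADME assay on microsomes from liver (Homo sapiens) for metabolic stability, read by LC-MS, tested at 0.5 uM (a higher number here means that the compound lasts longer, a lower number that the compound disappears faster), compound 1 reaches > 2 h, which is a limit of the assay rather than a number. Compound 2 also sits at a limit, > 2 h. Compound 3 likewise returns only a limit, > 2 h. Because of the limit of > 2 h in this assay, at which 3 of the 3 values shown sit, none of the three steps can be sized: a step that the two limits leave unreadable from compound 1 to compound 2, a step that the two limits leave unreadable from compound 1 to compound 3 and a step that the two limits leave unreadable from compound 2 to compound 3 are all unreadable.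

Compound 4 `Cc1nc(CCOc2ccc(-c3c(C)nc(C)c([C@H](OC(C)(C)C)C(=O)O)c3N3CCC(C)(C)CC3)cc2)cs1` is not yet measured. It differs from compound 3 by 2-(2-methyl-1,3-thiazol-4-yl)ethoxy in place of (2-(4-fluorophenyl)ethyl)sulfanyl on an aromatic carbon. The measured steps, all unreadable, bear on it only by showing that three different side chains on this position all stayed at the limit, so no direction or size can be read for this assay from them.

The expectation for compound 4 is therefore a half-life near the limit, estimated at 2 h with a range of 1 h to 4 h, an expected step of a number no higher from compound 3 to compound 4 (the limit leaves the size open) from compound 3.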

Compound 4, half-life: 0.683 h
For compound 4 the middle estimate is 2.9-fold (0.47 log units) above the measured one, and the stated range ends above it.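

Of the four compounds, only compound 4 comes off the limit, so the side chain at this position can shorten the half-life in this assay, and the swap gives an at least 2.9-fold lower number from compound 3 to compound 4 (0.46 log units; beyond the scatter). The narrowest comparison keeps the ether oxygen and exchanges only the end of the chain, 2-methyl-1,3-thiazol-4-yl in place of 4-fluorobenzyl, and gives an at least 2.9-fold lower number from compound 2 to compound 4 (0.46 log units; beyond the scatter), while the full exchange of the all-carbon side chain gives an at least 2.9-fold lower number from compound 1 to compound 4 (0.46 log units; beyond the scatter). Each of these steps is only a lower bound, because the starting compound in each pair has no exact value: the limit of > 2 h in this assay, at which 3 of the 4 values shown sit.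

From the compounds shown here alone, whether the loss belongs to the thiazole ring or to its methyl group stays open; a thiazole without that methyl, or a pyridine in its place, would separate the two. The compounds shown also do not tell why the half-life falls.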